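Sulfonamide substituent change from compound 2 to compound 3

This account rests on a few compounds, and the source may have more. Where it says the series, first, only, none or still open, it means among the compounds named here.

- compound 1 `Cc1ccc(NS(=O)(=O)c2cccc(CCCCCCNC(=O)/C=C/c3cccnc3)c2)cc1`: 2.98 nM
- compound 2 `O=C(/C=C/c1cccnc1)NCCCCCCc1cccc(S(=O)(=O)Nc2ccc(Cl)cc2)c1`: 6.41 nM
- compound 3 `O=C(/C=C/c1cccnc1)NCCCCCCc1cccc(S(=O)(=O)Nc2ccc(F)c(Cl)c2)c1`: not yet measured

In a functional assay on K562 cells (Homo sapiens) for inhibition, read by CCK-8 assay, with a stated time of 72 h (on this read-out lower numbers stand for stronger inhibition and higher numbers for weaker inhibition), compound 2 gives 6.41 nM. This is the higher of the two numbers and so the weaker result of the pair, set against compound 1 at 2.98 nM.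

The next structural change is 3-chloro-4-fluorophenyl in place of 4-chlorophenyl on a sulfonamide nitrogen, with 3-chloro-4-fluorophenyl in place of 4-chlorophenyl on a sulfonamide nitrogen. Among the measured compounds shown here, only one measured step bears on it: a 2.2-fold higher number from compound 1 to compound 2 (0.33 log units; beyond the scatter), with chloro in place of methyl on an aromatic carbon. That step was modest, and it is a different substitution, so it offers only a rough guide to size and none to direction. Two compounds cannot establish a trend for this group. No shift beyond the scatter is therefore expected in this assay, and no direction is favoured.

The expected change is a 1.1-fold lower number from compound 2 to compound 3 (0.03 log units; within the scatter).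

For compound 3 the estimated value is 6 nM, with an expected range of 2.5 nM to 15 nM.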

Compound 3, half-maximal inhibitory concentration: 5.31 nM
Beside the measured number, compound 3's estimate is 1.1-fold (0.05 log units) above it; the range from low to high includes it.
By their numbers in this assay, from the lowest: compounds 1, 3 and 2 (each within the scatter of the next, the first and the last beyond it).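

In this assay, 3-chloro-4-fluorophenyl in place of 4-chlorophenyl on a sulfonamide nitrogen gives a 1.2-fold lower number from compound 2 to compound 3 (0.08 log units; within the scatter) so this position accepts 8 heavy atoms in place of 7 with no shift that can be told from the scatter. Read from the 4-methylphenyl group, the same new group gives a 1.8-fold higher number from compound 1 to compound 3 (0.25 log units; within the scatter) so it cannot be ordered against either earlier group, even though those two stand apart by a 2.2-fold higher number from compound 1 to compound 2 (0.33 log units; beyond the scatter) in this series. The three aryl groups therefore form a narrow set at this position, and nothing at hand accounts for the result.

Only the combined chloro and fluoro pattern is shown, so the separate share of each halogen stays open, and a phenyl group carrying fluoro alone or chloro alone on the same nitrogen would address it. As far as these compounds go, it also remains open how far this position tolerates departures from a halogen- or methyl-bearing phenyl group, such as a methoxy group, a carboxylic acid or an amine on the ring, or a pyridine ring in place of the phenyl.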